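A few compounds are considered here, and "the series" means these few. Any claim that something is new, unique, unknown or untested is made for them only; others in the source may bear on it.

Compound 2 `COc1ncnc2c1c(I)cn2[C@@H]1O[C@H](CO)[C@@H](O)[C@H]1O` carries an iodo group on its core. In a functional assay on K562 cells (Homo sapiens), read by MTT assay, with a stated time of 72 h (on this read-out higher numbers stand for weaker inhibition and lower numbers for stronger inhibition), compound 2 gives 14800 nM. Of the two measured compounds it has the highest number, which on this read-out means the weaker inhibition. Among the measured compounds shown here, its only measured neighbour is compound 1 `C#Cc1cn([C@@H]2O[C@H](CO)[C@@H](O)[C@H]2O)c2ncnc(OC)c12`, which differs from it at that one place by carrying an ethynyl group; in this assay compound 1 gives 380 nM. The step between them, a 39-fold higher number from compound 1 to compound 2 (1.59 log units; beyond the scatter), shows that the iodo group comes with a markedly weaker result than the ethynyl group.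

Compound 3 `COc1ncnc2c1c(-c1ccco1)cn2[C@@H]1O[C@H](CO)[C@@H](O)[C@H]1O` is the compound still to be measured. Its difference from compound 2 is furan-2-yl in place of iodo on an aromatic carbon. For the measured compounds named here, only one measured step touches this position, and it says that putting iodo in place of ethynyl raised the number a great deal. Taking iodo away again in favour of a furan-2-yl ring is the reverse kind of exchange, so the number is expected to fall, though no measured pair with a furan-2-yl group tells how far. The step is therefore estimated as a 49-fold lower number from compound 2 to compound 3 (1.69 log units; beyond the scatter). For compound 3 the expected value in this assay is 300 nM, with a range from 30 nM to 3000 nM.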

Compound 3, half-maximal inhibitory concentration: 380 nM
For compound 3 the middle estimate is 1.3-fold (0.10 log units) below the measured one; the range from low to high includes it.
By their numbers in this assay, from the lowest: compounds 1 and 3 (each within the scatter of the next); then compound 2.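

The furan-2-yl ring on this aromatic carbon of the five-membered ring gives a 39-fold lower number from compound 2 to compound 3 (1.59 log units; beyond the scatter) in this assay, so replacing iodo with a larger group that brings its own aromatic ring and a hydrogen-bond acceptor does not weaken the result here; it goes with a much stronger one. Setting this ring in place of the ethynyl group gives no change at the digits printed from compound 1 to compound 3 (within the scatter), which means that the low number seen with compound 1 is not unique to ethynyl and that this position accepts two quite different groups with no difference that can be read in this assay. Among these three compounds, only the iodo group of compound 2 goes with the high number, but the data offer no measured explanation for why iodo differs from the other two groups.

As far as these compounds go, whether the number would stay low with an amine, a carboxylic acid or a longer chain on this carbon remains open. From the compounds shown here alone, it is also open whether a phenyl ring or a thiophene ring would match the furan-2-yl ring, which would show how much the ring's oxygen matters.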